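A few compounds are considered here, and "the series" means these few. Any claim that something is new, unique, unknown or untested is made for them only; others in the source may bear on it.

Values measured in a functional assay on HL-60 cells (Homo sapiens) for inhibition, read by resazurin assay, with a stated time of 72 h; on this read-out lower numbers stand for stronger inhibition and higher numbers for weaker inhibition

compound 1 `CCOc1ccc(C2C(C3CC3)C(=O)N2c2cc(OC)c(OC)c(OC)c2)cc1` gives 201 nM
compound 2 `C=CC1C(=O)N(c2cc(OC)c(OC)c(OC)c2)C1c1ccc(SC)cc1` gives 61 nM
compound 3 `CCOc1ccc(C2C(O)C(=O)N2c2cc(OC)c(OC)c(OC)c2)cc1` gives 11 nM

Compound 3 (11 nM) has the lowest number of the three, so it shows the strongest inhibition here. Compound 2 (61 nM) comes nearest to it, and compound 1 (201 nM) lies furthest away.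

The next structure, compound 4 `C=CC1C(=O)N(c2cc(OC)c(OC)c(OC)c2)C1c1ccc(OCC)cc1`, keeps the 4-ethoxyphenyl group of compound 3 and has vinyl in place of hydroxy on a saturated ring carbon. Among the measured compounds shown here, one measured step bears directly on this change. It is an 18-fold lower number from compound 1 to compound 3 (1.26 log units; beyond the scatter), with hydroxy in place of cyclopropyl on a saturated ring carbon. Read backwards, it suggests that losing the hydroxy will raise the number. Compound 2 also carries vinyl, though not the 4-ethoxyphenyl group, and its value (61 nM) suggests a rise smaller than the one seen with cyclopropyl. The expected change, towards weaker inhibition and beyond the scatter, is a 5.5-fold higher number from compound 3 to compound 4 (0.74 log units; beyond the scatter).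

Compound 4 is estimated at 60 nM (expected range 20 nM to 180 nM).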

Compound 4, half-maximal inhibitory concentration: 35 nM
Compound 4: middle estimate off by 1.7-fold (0.23 log units), on the high side; the range from low to high includes it.
By their numbers in this assay, from the lowest: compound 3; then compounds 4 and 2 (each within the scatter of the next); then compound 1.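

In this assay, the step of a 3.2-fold higher number from compound 3 to compound 4 (0.50 log units; beyond the scatter) shows that this saturated ring carbon favours hydroxy over vinyl, yet the loss is only modest. Vinyl still holds an advantage over cyclopropyl, as a 5.7-fold lower number from compound 1 to compound 4 (0.76 log units; beyond the scatter) shows, so a low number here does not depend on a group with a hydrogen-bond donor. With vinyl held in place, a 1.7-fold lower number from compound 2 to compound 4 (0.24 log units; within the scatter) lies within the scatter, so ethoxy and methylsulfanyl on the aromatic carbon cannot be told apart in these two compounds.

Nothing shown here gives a measured reason for these differences. From the compounds shown here alone, it remains open how an amine or a saturated ethyl group on the same ring carbon would compare, and the ethyl group would test whether the double bond of vinyl matters.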